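The source may report more compounds than this note shows. Statements on the series, on what has been measured and on what is new or still open speak of the compounds shown alone.

Of the compounds shown here, three of a shared amide series have been measured in a functional assay on CHO cells for inhibition of transient receptor potential cation channel subfamily V member 1 (Homo sapiens); a lower number here means a stronger inhibitor, a higher number a weaker inhibitor. Compound 1 `CC(C)(C)c1ccc(/C(=C/C(=O)Nc2ccc3c(c2)OCCO3)Cc2ccccc2)cc1` gives 110 nM. Compound 2 `CC(C)(C)c1ccc(/C=C/C(=O)Nc2ccc3c(c2)NC(=O)CC3)cc1` gives 71 nM. Compound 3 `CC(C)c1ccc(/C=C/C(=O)Nc2ccc3c(c2)OCCO3)cc1` gives 82 nM. On these three numbers compound 3 stands second highest, but its distance to compound 2 and its distance to compound 1 both lie within the usual scatter of repeated measurements, so the three values cannot be ranked against one another; they read as essentially the same level of inhibition.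

The next compound keeps the core of compound 3 and alters only the group on the far aromatic ring. Compound 4 `O=C(/C=C/c1ccc(Cl)cc1)Nc1ccc2c(c1)OCCO2` carries a chloro in place of isopropyl on an aromatic carbon. For the measured compounds named here, no pair of measured compounds differs at that position alone, so there is no measured step to lean on. Given that compound 1, compound 2 and compound 3 all carry a branched alkyl group there and all sit near 82 nM, a clear loss of inhibition is expected when that group shrinks to a single chlorine, with the estimated step from compound 3 to compound 4 being a 3.7-fold higher number from compound 3 to compound 4 (0.56 log units; beyond the scatter). Compound 4 is therefore expected to give about 300 nM, within a range from 100 nM to 900 nM.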

Compound 4, half-maximal inhibitory concentration: 320 nM
For compound 4 the middle estimate is 1.1-fold (0.03 log units) below the measured one, within the range that was stated.
By their numbers in this assay, from the lowest: compounds 2, 3 and 1 (each within the scatter of the next); then compound 4.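

For the compounds shown here, replacing isopropyl with chloro on an aromatic carbon, with the rest of compound 3 unchanged, is the first change that can be read on its own, and in this assay it gives (a 3.9-fold higher number from compound 3 to compound 4 (0.59 log units; beyond the scatter)). Going by these compounds alone, the step lies beyond the scatter, so what sits at this place on the ring does affect the result, something the earlier compounds could not show, as their numbers lie within the scatter of one another and no two of them differ in one place only. The swap takes away three carbons and brings in one chlorine, neither group has hydrogen-bond donors or acceptors, and nothing measured here explains the step.

One pair cannot tell whether the change in number comes from losing the isopropyl or from gaining the chlorine, and a methyl, methoxy or trifluoromethyl group at the same place on the core of compound 3 would help separate the two. On these data alone, it also remains open whether chloro in place of a branched alkyl group would have a similar effect on the core of compound 2.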